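The source may report more compounds than this note shows. Statements on the series, on what has been measured and on what is new or still open speak of the compounds shown alone.

Among the measured compounds shown here, compound 3, `CC(=O)N1N=C(c2ccc(N3CCN(C)CC3)cc2)CC1c1ccc(N(C)C)cc1`, is one of three compounds measured in a functional assay on HCC1806 cells (Homo sapiens) for inhibition, read by sulforhodamine B assay, tested at 10 uM (a higher number here means more inhibition at the concentration tested (going by the name of the read-out), a lower number less inhibition), where it gives -0.8%. That is the second highest of the three numbers: compound 1, `CN(C)c1ccc(C2CC(c3ccc(-n4cncn4)cc3)=NN2)cc1`, gives 6.8%, which lies within the scatter of compound 3, while compound 2, `CN(C)c1ccc(C2CC(c3ccc(-n4ccnc4)cc3)=NN2)cc1`, gives -20.9%, a gap beyond the scatter. For the measured compounds named here, the only measured step between close neighbours is a number 27.7 percentage points lower from compound 1 to compound 2 (beyond the scatter), where 1H-imidazol-1-yl stands in place of 1H-1,2,4-triazol-1-yl on an aromatic carbon; it concerns a different part of the shared core and says nothing about the group on the carbonyl carbon.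

Compound 4, `Cc1ccc(C(=O)N2N=C(c3ccc(N4CCN(C)CC4)cc3)CC2c2ccc(N(C)C)cc2)cc1`, differs from compound 3 in just one place: 4-methylphenyl in place of methyl on a carbonyl carbon. Going by the values given here, no measured step touches this position, so there is no guide to its effect. The working expectation for compound 4 is therefore a step of a number 2.8 percentage points higher from compound 3 to compound 4 (within the scatter) in this assay, that is, none beyond the scatter. On that basis compound 4 is estimated at 2%, with a plausible range from -18% to 22%.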

Compound 4, a percentage reported as inhibition, at one concentration (the size of the read-out at that concentration, not a potency): -2.5%
Compound 4: the middle estimate sits 4.5 percentage points above what was measured; the range from low to high includes it.
By their numbers in this assay, from the lowest: compound 2; then compounds 4, 3 and 1 (each within the scatter of the next).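

Among the compounds shown here, putting 4-methylphenyl on the carbonyl carbon, with seven heavy atoms and a six-membered aromatic ring in place of the single carbon of methyl, gives a number 1.7 percentage points lower from compound 3 to compound 4 (within the scatter) in this assay, so this large change in the size of the group produces no step that can be told from the scatter. The position is therefore no longer unknown: in this pair, going from acetyl to (4-methylphenyl)carbonyl neither raises nor lowers inhibition at the concentration tested by a readable amount. Nothing available explains why the number stays put.

From the compounds shown here alone, both groups here contain only carbon and carry no hydrogen-bond donors or acceptors, so it remains open how an amine or a carboxylic acid-bearing chain on the same carbonyl carbon would read. Going by these compounds, whether any group at this position can lift inhibition clearly above that of compound 3 also remains open.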